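Trading chloro for trifluoromethyl in a well-tolerated compound

The source may hold more compounds than are shown below. What is called first, only, known or untested is meant among the compounds shown, and "the series" means these compounds.

In an ADME assay on Vero cells (Chlorocebus sabaeus) for cytotoxicity, read by MTT assay, with a stated time of 96 h (a lower number here means that less compound is tolerated, a higher number that more compound is tolerated), compound 1 `C/C(=N\NC(N)=S)c1ccc2[nH]c(-c3ccc(C(F)(F)F)cc3)nc2c1` gives 22000 nM and compound 2 `CC(=O)c1ccc2c(c1)nc(-c1ccc(C(F)(F)F)cc1)n2C1CCCCC1` gives 35000 nM. Compound 3 `C/C(=N\NC(N)=S)c1ccc2c(c1)nc(-c1ccc(Cl)cc1)n2C1CCCCC1` gives only a limit, > 100000 nM, and not a number.

Compound 4 `C/C(=N\NC(N)=S)c1ccc2c(c1)nc(-c1ccc(C(F)(F)F)cc1)n2C1CCCCC1` differs from compound 3 by having trifluoromethyl in place of chloro on an aromatic carbon, para to a large group (trifluoromethyl in place of chloro on an aromatic carbon). Going by the values given here, no measured pair shows this change on its own. Still, compound 1 at 22000 nM and compound 2 at 35000 nM both carry 4-(trifluoromethyl)phenyl, so a moderate drop in the tolerated concentration is expected. The expected change is an at least 1.8-fold lower number from compound 3 to compound 4 (0.25 log units; that floor lies within the scatter). For compound 4 the estimate is 55000 nM, with an expected range of 20000 nM to 100000 nM.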

Compound 4, half-maximal cytotoxic concentration: > 100000 nM
Compound 4 ended at the assay's limit (the forecaster's own chance of this, stated with the estimate: 30%); middle value at least 1.8-fold (0.25 log units) from the limit.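

In this assay 4-(trifluoromethyl)phenyl alone does not keep the number low: there is an at least 2.8-fold higher number from compound 2 to compound 4 (0.45 log units; beyond the scatter) on gaining the group of 7 heavy atoms, and an at least 4.5-fold higher number from compound 1 to compound 4 (0.65 log units; beyond the scatter) on gaining cyclohexyl in place of hydrogen on an aromatic nitrogen. The lower numbers of compound 1 and compound 2 therefore go with those two places, not with trifluoromethyl. The chloro to trifluoromethyl step itself cannot be read, because compound 3 and compound 4 both stop at a limit: the limit of > 100000 nM in this assay, at which 2 of the 4 values shown sit.

As far as these compounds go, how far past that limit either compound lies stays open. From the compounds shown here alone, it is also open whether an amine or a methoxy group on that same aromatic carbon would bring the number into the measurable range.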